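Acetyl for Ethoxy on the Shared Core: a Cytotoxicity Outlook

A few compounds are considered here, and "the series" means these few. Any claim that something is new, unique, unknown or untested is made for them only; others in the source may bear on it.

Compound 1 `CCOC(=O)c1c(-c2cccc(OCC)c2)[nH]c2cc(OC)ccc2c1=O` — in this assay a limit only, > 21500 nM.
Compound 2 `CCOC(=O)c1c(-c2cccc(Cl)c2)[nH]c2cc(OC)ccc2c1=O` — in this assay a limit only, > 21500 nM.

In an ADME assay on HepG2 cells (Homo sapiens) for cytotoxicity, read by luminescence, with a stated time of 72 h (on this read-out higher numbers stand for an effect only at larger amounts of compound and lower numbers for an effect already at smaller amounts), compound 1 gives no number, only the limit > 21500 nM. Compound 2 likewise gives only the limit > 21500 nM. Within the data shown here, the one measured step, a step that the two limits leave unreadable from compound 1 to compound 2, is therefore unreadable, and the only evidence is the limit of > 21500 nM in this assay, at which 2 of the 2 values shown sit. Compound 3 `CCOC(=O)c1c(-c2cccc(C(C)=O)c2)[nH]c2cc(OC)ccc2c1=O` differs from compound 1 by acetyl in place of ethoxy on an aromatic carbon. With no readable step to rest on, compound 3 is expected to sit at the same limit, so the estimate is 30000 nM (range 10000 nM to 100000 nM), a step that the limit leaves unreadable from compound 1 to compound 3 expected to stay within the scatter.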

Compound 3, half-maximal effective concentration: > 21500 nM
Compound 3: no number, only a limit; the forecaster's own chance of this, stated with the estimate: 80%; the middle value does not contradict the limit.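

In this assay, among these compounds, compound 3, like compound 1 and compound 2, gives only a limit, so no step among them can be read. The compounds shown leave open whether ethoxy, chloro or acetyl makes any difference to cytotoxicity on the shared core.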